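The compounds below may be only part of what the source reports. "The series", "measured", "known", "first", "only" and "open" are said of these compounds alone.

Measured compounds:
- compound 1 `CCOc1ccc2oc(/C=C/[S+](C)[O-])cc(=O)c2c1`: 4900 nM in a functional assay on DLD-1 cells (Homo sapiens) for cytotoxicity, with a stated time of 48 h; on this read-out higher numbers stand for weaker inhibition and lower numbers for stronger inhibition
- compound 2 `C[S+]([O-])/C=C/c1cc(=O)c2ccccc2o1`: 8000 nM in this assay
- compound 3 `C[S+]([O-])/C=C/c1cc(=O)c2cc(Cl)ccc2o1`: 6500 nM in this assay

Compound 2 gives the highest of the three numbers, yet its gap to compound 3 a 1.2-fold lower number from compound 2 to compound 3 (0.09 log units; within the scatter) and the step of a 1.6-fold higher number from compound 1 to compound 2 (0.21 log units; within the scatter) both stay within the scatter, so no order among the three is established. Compound 4 `CC(C)Oc1ccc2oc(/C=C/[S+](C)[O-])cc(=O)c2c1` is not yet measured. It differs from compound 2 by isopropoxy in place of hydrogen on an aromatic carbon. Among the measured compounds shown here, the one measured step that bears on this change is the removal of ethoxy from compound 1, a 1.6-fold higher number from compound 1 to compound 2 (0.21 log units; within the scatter), which did not exceed the scatter; the chloro step a 1.3-fold higher number from compound 1 to compound 3 (0.12 log units; within the scatter) was likewise small. An alkoxy group entering at this place is therefore expected to move the number little, if at all: the expected step of a 1.5-fold lower number from compound 2 to compound 4 (0.16 log units; within the scatter) lies within the scatter. Compound 4 is estimated at 5500 nM in this assay, in the range 2500 nM to 12000 nM.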

Compound 4, half-maximal inhibitory concentration: 8000 nM
Beside the measured number, compound 4's estimate is 1.5-fold (0.16 log units) below it; low and high end bracket the measured number.
By their numbers in this assay, from the lowest: compounds 1, 3, 2 and 4 (each within the scatter of the next).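

Isopropoxy can now be read directly against hydrogen at this place in this assay: no change at the digits printed from compound 2 to compound 4 (within the scatter), and against chloro, a 1.2-fold higher number from compound 3 to compound 4 (0.09 log units; within the scatter). Branching the alkoxy chain adds no separation either, with a 1.6-fold higher number from compound 1 to compound 4 (0.21 log units; within the scatter), so hydrogen, chloro, ethoxy and isopropoxy are not told apart at this place on this read-out. No measurement shown gives a reason for this. Still open, going by these compounds, is whether an amine, a carboxylic acid or a longer alkoxy chain at this place would move the number beyond the scatter.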